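The compounds below may be only part of what the source reports. "The series", "measured", "known", "first", "only" and "open" are said of these compounds alone.

Working notes on the series. In an assay on membranes from CHO cells for displacement of a labelled ligand from adenosine receptor A1 (Homo sapiens), read by scintillation counting, with a stated time of 60 min, tested at 1 uM (on this read-out lower numbers stand for less inhibition and higher numbers for more inhibition at the one concentration tested (going by the name of the read-out)), compound 1 `CC1=C(C(=O)C2CC2)C(c2ccsc2)NC(=O)N1` gives 2%, compound 2 `CC1=C(C(N)=O)C(c2ccoc2)NC(=O)N1` gives 1%, and compound 3 `CC1=C(C(N)=O)C(c2ccsc2)NC(=O)N1` gives 2%. Compound 2 has the lowest of the three numbers, but its gaps to compound 1 and to compound 3 are within the scatter, so no order among them is claimed. Compound 4 `CC1=C(C(=O)OCC2CC2)C(c2ccoc2)NC(=O)N1` differs from compound 2 by cyclopropylmethoxy in place of amino on a carbonyl carbon. Among the measured compounds shown here, the one measured step at the same place, no change at the digits printed from compound 1 to compound 3 (within the scatter), did not move the read-out; the other step, a number 1 percentage points higher from compound 2 to compound 3 (within the scatter), concerns a different position. For the measured compounds named here, no step in this set has moved this assay beyond the scatter, so for compound 4 the expected step is a number 2 percentage points higher from compound 2 to compound 4 (within the scatter), with an estimate of 3% in the range 0% to 12%.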

Compound 4, a percentage reported as inhibition, at one concentration (the size of the read-out at that concentration, not a potency): 29%
Compound 4: middle estimate off by 26 percentage points, on the low side, and the stated range ends below it.
By their numbers in this assay, from the lowest: compounds 2, 1 and 3 (each within the scatter of the next); then compound 4.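

Among the compounds shown here, on a carbonyl carbon, cyclopropylmethoxy in place of amino gives the first step in this set beyond the scatter in this assay (a number 28 percentage points higher from compound 2 to compound 4 (beyond the scatter)). This place can therefore move the read-out, although the amino in place of cyclopropyl change there did not (no change at the digits printed from compound 1 to compound 3 (within the scatter)). No measured evidence bears on the reason for this step.

As far as these compounds go, it remains open whether methoxy or a longer chain such as butoxy on the same carbonyl carbon gives a step of this size. Also open, from the compounds shown here alone, is whether the step holds with thiophen-3-yl in place of furan-3-yl.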